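A few compounds are considered here, and "the series" means these few. Any claim that something is new, unique, unknown or untested is made for them only; others in the source may bear on it.

Working notes on the series.

Of the compounds shown here, two have been measured so far. Compound 1 `COc1cc(C)cc(-c2c(-c3ccnc(-c4ccc(N(C)C)cc4)c3)cnn2CC#N)c1` gives 28% in a functional assay on NCI-H23 cells (Homo sapiens) for cytotoxicity, read by sulforhodamine B assay, with a stated time of 48 h, tested at 100 nM; on this read-out higher numbers stand for a weaker effect at the one concentration tested and lower numbers for a stronger effect. Compound 2 `COc1cc(C)cc(-c2nn(CC#N)cc2-c2ccnc(-c3ccc(N(C)C)cc3)c2)c1` gives 31% in the same assay. The two numbers differ by an amount that falls within the usual scatter of the method, so compound 1 cannot be set apart from compound 2 on this read-out; both stand at the same level of effect at the single concentration tested.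

Compound 3 `COc1cc(C)cc(-c2c(-c3ccnc(-c4ccc(C(C)=O)cc4)c3)cnn2CC#N)c1` has not yet been measured. It departs from compound 1 in one place, (acetyl in place of dimethylamino on an aromatic carbon), that is, acetyl in place of dimethylamino on an aromatic carbon of a six-membered aromatic ring of carbon only. Going by the values given here, no measured pair shows this change, so there is no step to lean on. The expected step from compound 1 to compound 3 is a number 7 percentage points higher from compound 1 to compound 3 (within the scatter), which is taken to lie within the scatter, with no clear direction. Compound 3 is therefore estimated at 35%, with a range from 15% to 60%.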

Compound 3, a percentage reported as activity, at one concentration (the size of the read-out at that concentration, not a potency): 95%
Estimate against measurement, compound 3: 60 percentage points below, and the stated range ends below it.
By their numbers in this assay, from the lowest: compounds 1 and 2 (each within the scatter of the next); then compound 3.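

Going by these compounds alone, at this position, on an aromatic carbon para to a large group, the substituent matters strongly in this assay: acetyl in place of dimethylamino gives a number 67 percentage points higher from compound 1 to compound 3 (beyond the scatter), a large loss of effect at the single concentration tested that compounds 1 and 2 could not reveal. The change is not one of size as counted, since the two groups match in heavy atoms and hydrogen-bond acceptors and neither carries a net charge; they differ in that nitrogen gives way to oxygen and the acetyl brings a double bond outside the aromatic rings. Nothing measured on these compounds bears on why the step is so large, and it rests on this one pair alone.

Open, on these data alone, is whether the effect of compound 1 depends on dimethylamino itself or would survive with another group at this place, such as a primary amine, a diethylamino group or a methoxy group. Also open, as far as these compounds go, is whether a carboxylic acid or a longer chain here would fall nearer to compound 1 or to compound 3, and whether the same change carries over to the arrangement of compound 2.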